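Methyl branching on the ketone chain: working notes

The source may hold more compounds than are shown below. What is called first, only, known or untested is meant among the compounds shown, and "the series" means these compounds.

Measured in an assay on HEK293 cells for positive allosteric modulation of metabotropic glutamate receptor 2 (Rattus norvegicus), read by thallium flux, with a stated time of 2.5 min; on this read-out lower numbers stand for smaller maximal responses and higher numbers for larger maximal responses:
compound 1, `Cc1cc(C(=O)O)ccc1OCCCCOc1ccc(C(=O)CC(C)C)c(O)c1C`, gives 83.9%
compound 2, `CCCC(=O)c1ccc(OCCCCOc2ccc(C(=O)O)cc2C)c(C)c1O`, gives 79.3%
compound 3, `CCC(=O)c1ccc(OCCCCOc2ccc(F)c(C(=O)O)c2)c(C)c1O`, gives 66.6%

Compound 1 and compound 2 share a core and differ by methyl in place of hydrogen on a saturated chain carbon bound to two saturated chain carbons. The step that goes with it is a number 4.6 percentage points higher from compound 2 to compound 1 (within the scatter), so this branching leaves the maximal response essentially unchanged on this pair. The core of compound 3 differs from that of compound 2 in more than one place; the difference between the two cores is not broken down here. Compound 3 carries the lowest of the three numbers, and both gaps to compound 2 and compound 1 lie beyond the scatter.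

Compound 4, `Cc1c(OCCCCOc2ccc(F)c(C(=O)O)c2)ccc(C(=O)C(C)C)c1O`, is not yet measured. It differs from compound 3 by methyl in place of hydrogen on a saturated chain carbon bound to a carbonyl carbon and a saturated chain carbon. The surroundings of the place differ from the earlier pair: there the carbon was bound to two saturated chain carbons, here to a carbonyl carbon and a saturated chain carbon, so this is the same kind of change, not the same change. Set against a number 4.6 percentage points higher from compound 2 to compound 1 (within the scatter), the step is expected to be a number 3.4 percentage points higher from compound 3 to compound 4 (within the scatter), small and within the scatter, because the one measured branching gave a number 4.6 percentage points higher from compound 2 to compound 1 (within the scatter). Compound 4 is therefore estimated at 70%, with a range of 58% to 82% in this assay.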

Compound 4, largest response reached (reported as percent of maximum), in percent of the reference or control that the assay uses: 74.1%
For compound 4 the middle estimate is 4.1 percentage points below the measured one; low and high end bracket the measured number.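

In this assay the methyl branching on the second core gives a number 7.5 percentage points higher from compound 3 to compound 4 (within the scatter), and the two steps now available agree: the same change on two cores in this assay, a number 4.6 percentage points higher (within the scatter) from compound 2 to compound 1 and a number 7.5 percentage points higher (within the scatter) from compound 3 to compound 4, 2.9 percentage points apart, within the scatter of two such steps. On these two pairs, then, the change carries from one core to the other without a step beyond the scatter, even though the carbon that takes the methyl is bound to two saturated chain carbons in the first pair and to a carbonyl carbon and a saturated chain carbon in the second. Among the compounds shown here, this does not show that the change is without effect in general: it rests on only two pairs, these are the same kind of change and not the same change, and the read-out is the maximal response alone.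

The compounds shown leave open whether a tert-butyl or a cyclopropyl group in place of the isopropyl would stay within the same narrow range. Also open, as far as these compounds go, is whether the branching would carry over to a core with an amide in place of the carboxylic acid.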